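Exchanging one aromatic arm, maximal response still unknown

The source may report more compounds than this note shows. Statements on the series, on what has been measured and on what is new or still open speak of the compounds shown alone.

Three compounds have been measured in an in vitro functional assay on HEK285-7 cells for antagonist activity at prostaglandin D2 receptor 2 (Homo sapiens), read by BRET and beta-arrestin recruitment; on this read-out higher numbers stand for larger maximal responses and lower numbers for smaller maximal responses:

compound 1, `O=C(O)Cc1sc(Cc2ccccc2-c2ccccc2)nc1-c1ccc(Cl)cc1`, gives 50%
compound 2, `CS(=O)(=O)Nc1cccc(-c2nc(C(c3ccc(F)cc3)c3ccc(F)cc3)sc2CC(=O)O)c1`, gives 80%
compound 3, `COc1ccc(C(c2ccccn2)c2nc(-c3ccc(Cl)cc3)c(CC(=O)O)s2)cc1`, gives 80%

Compound 2 stands level with compound 3 at the digits shown, and the two together give the highest numbers of the three; compound 1 lies clearly lower, a gap beyond the usual scatter. No two of these compounds differ in one place only, so none of these gaps can be tied to a single structural change.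

Compound 4, `O=C(O)Cc1sc(C(c2ccc(F)cc2)c2ccc(F)cc2)nc1-c1ccnc(N2CCC2)c1`, is not yet measured. It differs from compound 2 in one place: 2-(azetidin-1-yl)pyridin-4-yl in place of 3-(methanesulfonamido)phenyl on an aromatic carbon. The change keeps the carboxymethyl group and the large group on the shared core and swaps only the aromatic carbon's substituent. Within the data shown here, with no matching step among the measured compounds, the expectation rests on compound 2 alone, and a small step downward, or none beyond the scatter, is expected in this assay, namely a number 10 percentage points lower from compound 2 to compound 4 (within the scatter). Compound 4 is therefore estimated at 70%, within 45% to 95%.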

Compound 4, largest response reached (reported as efficacy), in percent of the reference or control that the assay uses: 80%
For compound 4 the middle estimate is 10 percentage points below the measured one; low and high end bracket the measured number.
By their numbers in this assay, from the lowest: compound 1; then compounds 2, 3 and 4 (each within the scatter of the next).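

In this assay, putting 2-(azetidin-1-yl)pyridin-4-yl in place of 3-(methanesulfonamido)phenyl on this aromatic carbon gives no change at the digits printed from compound 2 to compound 4 (within the scatter). This is the only pair shown that differs in one place, and it reveals that at this position the maximal response can stay in the same range when the group that leaves, with its hydrogen-bond donor and its carbon-only aromatic ring, gives way to one with no hydrogen-bond donor, a ring nitrogen and a four-membered ring. No measurement shown gives a reason for this outcome.

This single step does not separate the contributions of the pyridine ring, the azetidine ring and the loss of the methanesulfonamido group, as all three changed together. As far as these compounds go, whether a piperidine ring in place of the azetidine ring, or a plain amine on the pyridine, would leave the response unchanged remains open.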